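Swapping a nitro group for chloro on a sulfonamide core

The source may hold more compounds than are shown below. What is called first, only, known or untested is meant among the compounds shown, and "the series" means these compounds.

Three members of a sulfonamide series have been tested for how strongly they damage a human cell line. In an ADME assay on HEK293 cells (Homo sapiens) for cytotoxicity, read by resazurin assay, with a stated time of 48 h (on this read-out higher numbers stand for lower toxicity in this test and lower numbers for higher toxicity in this test), compound 1 `O=[N+]([O-])c1cc(S(=O)(=O)Nc2ccc(-c3nc4ccccc4o3)cc2)ccc1Cl` gives 85000 nM, the higher of the two plain numbers in hand. Compound 2 `COc1ccc(Cl)cc1S(=O)(=O)Nc1ccc2oc(-c3ccccc3)nc2c1` gives 74000 nM in this assay, which lies within the scatter of the value for compound 1. Compound 3 `O=S(=O)(Nc1ccc(-c2nc3ccccc3o2)cc1)c1cccc(C(F)(F)F)c1` gives > 100000 nM in this assay. This value is the limit of > 100000 nM in this assay, at which 1 of the 3 values shown sits, so for compound 3 the read-out is a limit rather than a number.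

The next compound, compound 4 `O=S(=O)(Nc1ccc(-c2nc3ccccc3o2)cc1)c1ccc(Cl)c(Cl)c1`, is not yet measured. It differs from compound 1 in one place: chloro in place of nitro on an aromatic carbon. Within the data shown here, no measured pair here shows what such a change does, so the expectation rests on the narrow spread of the three results. The step from compound 1 to compound 4 is therefore expected to be small, a 1.1-fold higher number from compound 1 to compound 4 (0.05 log units; within the scatter), not beyond the scatter. Compound 4 is estimated to give about 95000 nM in this assay, somewhere between 50000 nM and 200000 nM.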

Compound 4, half-maximal cytotoxic concentration: > 100000 nM
Compound 4 was reported as a limit; the forecaster's own chance of this, stated with the estimate: 45%; middle value at least 1.0-fold (0.02 log units) away from the limit.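

Among these compounds, compounds 1 and 4 are the first pair here that differ in one place, so this assay can now be read directly for chloro in place of nitro on an aromatic carbon, ortho to a chloro group: the change gives an at least 1.1-fold higher number from compound 1 to compound 4 (0.07 log units; that floor lies within the scatter). Compound 4 gives > 100000 nM, which is a limit and not a number, so the step has a floor but no known size. At this position, the swap shows no sign of higher toxicity in this test, and the series now has a second compound at the top of the read-out: the limit of > 100000 nM in this assay, at which 2 of the 4 values shown sit.

Still open, going by these compounds, is whether an amine or a carboxylic acid at this position would keep the number this high. Also open, on these data alone, is whether the same swap would behave alike on the core of compound 2.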